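A Methyl Added to the Core of Compound 2

The source may report more compounds than this note shows. Statements on the series, on what has been measured and on what is new or still open speak of the compounds shown alone.

Measured compounds:
compound 1 `Cc1ccc2c(=O)n(C)c3c(c2c1)CCOc1ccccc1-3` gives 33600 nM in a functional assay on HL-60 cells (Homo sapiens) for cytotoxicity, read by sulforhodamine B assay; a lower number here means a stronger inhibitor, a higher number a weaker inhibitor
compound 2 `COCOc1ccccc1-c1cc2ccccc2c(=O)[nH]1` gives 620 nM in this assay

Compound 2 holds the lowest of the two numbers; compound 1 sits far above it, well beyond the scatter, on a different core. Compound 3 `COCOc1ccccc1-c1cc2cc(C)ccc2c(=O)[nH]1` differs from compound 2 by methyl in place of hydrogen on an aromatic carbon. Within the data shown here, no pair of measured compounds shows what this change alone does, so the expected step is none beyond the scatter. Compound 3 is expected to give about 600 nM, within 200 nM to 2000 nM. That estimate means an expected step of a 1.0-fold lower number from compound 2 to compound 3 (0.01 log units; within the scatter).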

Compound 3, half-maximal inhibitory concentration: 160 nM
The estimate for compound 3 lay 3.8-fold (0.57 log units) above the measured number; the whole stated range lies above it.
By their numbers in this assay, from the lowest: compound 3; then compound 2; then compound 1.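

In this assay, among these compounds, methyl in place of hydrogen on this aromatic carbon gives a modest step beyond the scatter, a 3.9-fold lower number from compound 2 to compound 3 (0.59 log units; beyond the scatter) and this is the first single change that can be read. So this carbon of the shared core is not indifferent to even one added carbon. Nothing at hand explains why the number falls.

From the compounds shown here alone, whether a longer chain such as ethyl, or an amine, on this same carbon would lower the number further remains open. So does whether methyl on the other carbons of this ring would act alike.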